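Acylguanidine series: amide nitrogen substituent and intrinsic activity

The source may hold more compounds than are shown below. What is called first, only, known or untested is meant among the compounds shown, and "the series" means these compounds.

Two members of the series carry a measured value in a functional assay on Right cardiac atrium for agonist activity at histamine H2 receptor (Cavia porcellus), with a stated time of 30 min, in the presence of a further agent that is not named here; a higher number here means a larger maximal response, a lower number a smaller maximal response. Compound 1, `Cc1nc(N)sc1CCCN/C(N)=N/C(=O)N[C@@H](C)c1ccccc1`, bears a 1-phenylethyl group on the amide-type nitrogen and in this assay compound 1 gives 1.08, the higher of the two numbers. Compound 2, `Cc1ccc(C(C)NC(=O)/N=C(\N)NCCCc2sc(N)nc2C)cc1`, carries the same kind of substituent with a methyl on its aromatic ring, and in this assay compound 2 gives 0.85, a number that lies beyond the scatter below compound 1.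

Among the compounds with values here, no pair of measured compounds differs in one place only, so no step within the set can be read directly. Compound 3, `Cc1nc(N)sc1CCCN/C(N)=N/C(=O)NCc1ccco1`, is not yet measured. It differs from compound 1 as follows: (furan-2-yl)methyl in place of 1-phenylethyl on an amide-type nitrogen

With the shared core held constant and only the substituent on the amide-type nitrogen exchanged, the maximal response is expected to stay close to that of compound 1; the step from compound 1 is estimated at a number 0.11 lower from compound 1 to compound 3 (beyond the scatter), within the scatter. For compound 3 the value in this assay is estimated at 0.97, with a range from 0.78 to 1.12.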

Compound 3, intrinsic activity: the largest response reached, as a fraction of the reference agonist's: 0.58
For compound 3 the middle estimate is 0.39 above the measured one; the measured number lies below the stated range.
By their numbers in this assay, from the lowest: compound 3; then compound 2; then compound 1.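

In this assay, within the data shown here, the substituent on the amide-type nitrogen turns out to have a strong hold on the maximal response: the exchange of 1-phenylethyl for (furan-2-yl)methyl gives a step of a number 0.50 lower from compound 1 to compound 3 (beyond the scatter) and this is the first step that can be read at a single place. The exchange is not a single structural change, since a six-membered aromatic ring of carbon only gives way to a five-membered aromatic ring with 1 hetero atom, the defined stereocentre is gone, and 6 heavy atoms stand in place of 8. Nothing available here ties the size of this step to any one of these differences.

The two compounds therefore leave open whether the step follows the ring, the stereocentre or the size of the group. A benzyl group on the same nitrogen, a (thiophen-2-yl)methyl group or a 1-(furan-2-yl)ethyl group would pull these differences apart, and the opposite stereoisomer of the 1-phenylethyl group would test the stereocentre alone.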